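The compounds below may be only part of what the source reports. "The series", "measured", "known", "first", "only" and "open" are said of these compounds alone.

Compound 2 `COc1cc2nnc(C(N)=O)c(Nc3ccc(C)cc3F)c2cc1N1C[C@@H](C)N[C@@H](C)C1` shows the lowest of the two clearances so far; its nearest neighbour, compound 1 `COc1cc2nnc(C(N)=O)c(Nc3ccc(C)cc3F)c2cc1N1CCN(C)CC1`, gives 12 mL/min/kg in an ADME assay on the whole organism for pharmacokinetics, with Rattus norvegicus as the target, at a dose of 10 mg/kg by the oral route (a lower number here means slower removal, a higher number faster removal of the compound), while compound 2 gives 4 mL/min/kg. Compound 3 `COc1cc2nnc(C(N)=O)c(Nc3ccc(C)cc3F)c2cc1N1CCC(N(C)C)CC1` differs from compound 2 by 4-(dimethylamino)piperidin-1-yl in place of 3,5-dimethylpiperazin-1-yl on an aromatic carbon. Within the data shown here, the only measured step that bears on this change is a 3.0-fold lower number from compound 1 to compound 2 (0.48 log units; beyond the scatter), and compound 3 returns to a group with 0 hydrogen-bond donors, as in compound 1. For compound 3 a modest rise back toward compound 1 is therefore expected, a 2.0-fold higher number from compound 2 to compound 3 (0.30 log units; within the scatter). Compound 3 is estimated at 8 mL/min/kg, within 4 mL/min/kg to 16 mL/min/kg.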

Compound 3, clearance: 34 mL/min/kg
Compound 3: middle estimate off by 4.3-fold (0.63 log units), on the low side; the measured number lies above the stated range.
By their numbers in this assay, from the lowest: compound 2; then compound 1; then compound 3.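

With 4-(dimethylamino)piperidin-1-yl on this aromatic carbon, ortho to a methoxy group, the number gives an 8.5-fold higher number from compound 2 to compound 3 (0.93 log units; beyond the scatter) and a 2.8-fold higher number from compound 1 to compound 3 (0.45 log units; beyond the scatter) in this assay across the series. Compound 1 and compound 3 carry the same count of hydrogen-bond donors in this group, yet their numbers stand apart beyond the scatter, so that count alone does not order the three compounds. The compounds shown leave open how a morpholine, or a piperidine bearing a primary amine instead of dimethylamino, would read here. What lies behind these steps also stays open, as no evidence bears on them.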